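The compounds below may be only part of what the source reports. "The series", "measured", "known", "first", "only" and "open" are said of these compounds alone.

Compound 1, `CC(C)=CCC[C@@](C)(/C=C/c1ccccc1)/C=C/c1ccc(O)cc1`: in an ADME assay on HEK293 cells (Homo sapiens) for cytotoxicity, with a stated time of 72 h (a higher number here means that more compound is needed for the effect, a lower number that less compound is needed), compound 1 gives > 36600 nM, which is a limit of the assay and not a number.
Compound 2, `CC(C)=CCC[C@](C)(/C=C/c1ccc(O)cc1)/C=C/c1cccc(Cl)c1`: in this assay compound 2 gives > 36600 nM, again a limit.
Compound 3, `C=C[C@@](C)(/C=C/c1ccc(Nc2ccc(Cl)cc2)cc1)CCC=C(C)C`: in this assay compound 3 gives > 36600 nM, also a limit.

All three measured compounds therefore sit at the same point: the limit of > 36600 nM in this assay, at which 3 of the 3 values shown sit. Compound 1 and compound 2 differ in one place, (chloro in place of hydrogen on an aromatic carbon). Since both values are limits, the step that the two limits leave unreadable from compound 1 to compound 2 cannot be read in size. Compound 3 rests on a different core; the difference between the core of compound 1 and that of compound 3 is not broken down here.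

Compound 4, `C=C[C@@](C)(/C=C/c1ccc(Nc2ccc(Cl)c(Cl)c2)cc1)CCC=C(C)C`, has not yet been measured. It differs from compound 3 by chloro in place of hydrogen on an aromatic carbon. Among the compounds with values here, this is the same kind of change as the one from compound 1 to compound 2, but not the same change: in compound 4 the entering chloro sits ortho to a chloro group and meta to a large group, whereas in compound 2 it sits meta to a large group only.

In this assay the step that the limit leaves unreadable from compound 3 to compound 4 is expected. That expectation rests on (the limit of > 36600 nM in this assay, at which 3 of the 3 values shown sit), where every measured compound stands, and on the step that the two limits leave unreadable from compound 1 to compound 2, which gave nothing readable. Compound 4 is thus estimated at 50000 nM, most likely reported once more as a limit, within a range from 20000 nM to 150000 nM.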

Compound 4, half-maximal effective concentration: > 36600 nM
Compound 4: only a limit was reported; the forecaster's own chance of this, stated with the estimate: 90%; the middle value lies beyond the limit too.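

In this assay compound 4 gives > 36600 nM, which is a limit of the assay and not a number. Compound 3 also stands at a limit, so the step between compound 3 and compound 4 cannot be read in size. The same holds across the series: the limit of > 36600 nM in this assay, at which 4 of the 4 values shown sit. The compounds shown leave open how much of any of them is needed for the effect, and whether chloro in place of hydrogen changes that amount at all.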